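Working notes: from compound 2 to compound 3

A few compounds are considered here, and "the series" means these few. Any claim that something is new, unique, unknown or untested is made for them only; others in the source may bear on it.

Compound 1 `COc1ccc(/C=C\c2cc(OC)c(OC)c(OC)c2)cc1OCc1ccccc1`: 39000 nM
Compound 2 `COc1cccc(/C=C/CCCOc2cc(/C=C\c3cc(OC)c(OC)c(OC)c3)ccc2OC)c1`: 25000 nM

Both values come from a functional assay on HT-29 cells (Homo sapiens) for inhibition, read by MTT assay, with a stated time of 3 days; a higher number here means a weaker inhibitor, a lower number a stronger inhibitor. For the measured compounds named here, compound 2 stands level with compound 1 on these numbers, and no other measured compound is available for comparison. Going by the values given here, the only measured step, a 1.6-fold lower number from compound 1 to compound 2 (0.19 log units; within the scatter), put 4-(3-methoxyphenyl)but-3-en-1-yl in place of phenyl on a saturated chain carbon bound to an oxygen on an aromatic ring.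

Compound 3 `COCOc1ccccc1/C=C/CCCOc1cc(/C=C\c2cc(OC)c(OC)c(OC)c2)ccc1OC` has not yet been measured. Its change from compound 2 is 2-(methoxymethoxy)phenyl in place of 3-methoxyphenyl on a double-bonded chain carbon bound to a double-bonded chain carbon.

Among the compounds with values here, no measured step makes this swap, and no measured compound carries 2-(methoxymethoxy)phenyl. Within the data shown here, the one related piece of evidence is that the much larger change in a 1.6-fold lower number from compound 1 to compound 2 (0.19 log units; within the scatter) stayed within the scatter. A shift beyond the scatter is therefore not expected, and the estimated step is a 1.1-fold lower number from compound 2 to compound 3 (0.06 log units; within the scatter). This expectation rests on a single step, so the range is kept wide. In this assay compound 3 is expected at 22000 nM, with an estimated range from 8000 nM to 50000 nM.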

Compound 3, half-maximal inhibitory concentration: 9600 nM
For compound 3 the middle estimate is 2.3-fold (0.36 log units) above the measured one; low and high end bracket the measured number.
By their numbers in this assay, from the lowest: compound 3; then compounds 2 and 1 (each within the scatter of the next).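

For the compounds shown here, the aryl group on a double-bonded chain carbon bound to a double-bonded chain carbon is a place where the number in this assay can move: 2-(methoxymethoxy)phenyl in place of 3-methoxyphenyl gives a 2.6-fold lower number from compound 2 to compound 3 (0.42 log units; beyond the scatter), whereas the only earlier step, a 1.6-fold lower number from compound 1 to compound 2 (0.19 log units; within the scatter), showed no change that could be told from the scatter. This change alters two things at once, since the ring substituent and the number in the group's name both differ, with 10 heavy atoms and 2 hydrogen-bond acceptors entering where 8 and 1 leave, and this single step cannot assign the shift to either difference. Nothing available explains the shift.

The compounds shown leave open whether the lower number follows the methoxymethoxy group or its placing on the ring, a question that 2-methoxyphenyl and 3-(methoxymethoxy)phenyl would separate. Also open, as far as these compounds go, is how a free hydroxyl or an amine in place of the methoxymethoxy group would read in this assay, and whether a longer chain to the aryl group would shift the number further.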